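A few compounds are considered here, and "the series" means these few. Any claim that something is new, unique, unknown or untested is made for them only; others in the source may bear on it.

Measured so far:
- compound 1 `CC(C)OC(=O)NCCS(=O)(=O)NC(=O)c1ccc(Nc2nc(NC3(c4ccc(Cl)cc4)CC3)nc(OCC(F)(F)F)n2)cc1`: 100%
- compound 2 `NCCS(=O)(=O)NC(=O)c1ccc(Nc2nc(NC3(c4ccc(Cl)cc4)CC3)nc(OCC(F)(F)F)n2)cc1`: 100%
- compound 3 `O=C(NS(=O)(=O)CCNCc1ccccc1)c1ccc(Nc2nc(NC3(c4ccc(Cl)cc4)CC3)nc(OCC(F)(F)F)n2)cc1`: 99%

In an ADME assay on microsomes from liver (Homo sapiens) for metabolic stability, with a stated time of 10 min (on this read-out lower numbers stand for a less stable compound and higher numbers for a more stable compound), compound 3 stands together with the other two: the steps of a number 1 percentage points lower from compound 1 to compound 3 (within the scatter) and a number 1 percentage points lower from compound 2 to compound 3 (within the scatter) are both within the scatter, as is no change at the digits printed from compound 1 to compound 2 (within the scatter). Every exchange made so far on the amine nitrogen of the side chain has left the read-out flat.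

Compound 4 `CC(C)NCCS(=O)(=O)NC(=O)c1ccc(Nc2nc(NC3(c4ccc(Cl)cc4)CC3)nc(OCC(F)(F)F)n2)cc1` differs from compound 3 by isopropyl in place of benzyl on an amine nitrogen. All three measured steps concern the same amine nitrogen and carry groups as different as a hydrogen, a benzyl and an isopropoxycarbonyl without moving the number; isopropyl is a smaller exchange than any of them. No step beyond the scatter is therefore expected in this assay. Compound 4 is estimated at 99% (range 90% to 100%), the expected step being no change at the digits printed from compound 3 to compound 4 (within the scatter).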

Compound 4, percent of the compound remaining in the liver assay: 89%
For compound 4 the middle estimate is 10 percentage points above the measured one; the whole stated range lies above it.
By their numbers in the liver assay, from the lowest: compounds 4, 3, 1 and 2 (each within the scatter of the next, the first and the last beyond it).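

In the liver assay this amine nitrogen does not tolerate every group equally: isopropyl brings a number 11 percentage points lower from compound 2 to compound 4 (beyond the scatter) and a number 11 percentage points lower from compound 1 to compound 4 (beyond the scatter) but only a number 10 percentage points lower from compound 3 to compound 4 (within the scatter) against benzyl. In a physicochemical assay for permeability, using PAMPA, at pH 7.4 (on this read-out higher numbers stand for higher permeability and lower numbers for lower permeability), compound 3 gives 49 nm/s and compound 4 gives 45 nm/s and the two stand within the scatter. Open, on these data alone, is whether tert-butyl or cyclopropyl on this amine nitrogen would take the number in the liver assay lower still. No measurement offered here explains the position of the isopropyl compound.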